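Straight Four-Carbon Chain in Place of a Branched One

The compounds below may be only part of what the source reports. "The series", "measured", "known", "first", "only" and "open" are said of these compounds alone.

Three compounds sharing one core have been tested in an ADME assay on the whole organism with Oryza sativa as the target, tested at 10 uM; a higher number here means a weaker effect of the compound at the concentration tested, a lower number a stronger effect:

compound 1 `CCc1ccc(NC(=O)N[C@@H](C)c2ccccc2)cc1` gives 91%
compound 2 `CC(C)c1ccc(NC(=O)N[C@@H](C)c2ccccc2)cc1` gives 86%
compound 3 `C[C@H](NC(=O)Nc1ccc(C(C)(C)C)cc1)c1ccccc1` gives 64%

Compound 3 stands lowest of the three, which in this assay means the strongest effect; its nearest neighbour is compound 2, and compound 1 lies furthest away. The next compound, compound 4 `CCCCc1ccc(NC(=O)N[C@@H](C)c2ccccc2)cc1`, differs from compound 3 in one place: butyl in place of tert-butyl on an aromatic carbon. The same atoms are present, but the four carbons now form a straight chain instead of a branched group on an aromatic carbon of a six-membered aromatic ring of carbon only.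

Going by the values given here, no measured step exchanges butyl for tert-butyl directly. Among the compounds with values here, the steps that bear on it are a number 27 percentage points lower from compound 1 to compound 3 (beyond the scatter) and a number 22 percentage points lower from compound 2 to compound 3 (beyond the scatter), both beyond the scatter, while a number 5 percentage points lower from compound 1 to compound 2 (within the scatter) was within it. The numbers fall as the group bound to the aromatic carbon becomes more branched, and compound 4 moves the other way, back toward a straight chain like that of compound 1. Compound 4 is therefore expected to give a number higher than compound 3, a step of about a number 18 percentage points higher from compound 3 to compound 4 (beyond the scatter). The estimated value for compound 4 is 82%, with a range from 64% to 96%.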

Compound 4, a percentage reported as activity, at one concentration (the size of the read-out at that concentration, not a potency): 60%
The estimate for compound 4 lay 22 percentage points above the measured number; measured number below the stated range.
By their numbers in this assay, from the lowest: compounds 4 and 3 (each within the scatter of the next); then compounds 2 and 1 (each within the scatter of the next).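

Read in this assay the same four carbons, rearranged from tert-butyl to butyl on the aromatic carbon, give no change that stands out from the scatter (a number 4 percentage points lower from compound 3 to compound 4 (within the scatter)). Branching on its own therefore does not account for the earlier fall in the numbers, since the straight butyl chain also lies well below the ethyl and isopropyl compounds (a number 26 percentage points lower from compound 2 to compound 4 (beyond the scatter); a number 31 percentage points lower from compound 1 to compound 4 (beyond the scatter)), and across these four compounds the two groups of four carbons sit together at the low end, whatever their shape. Nothing measured here bears on why this position responds in this way.

The compounds shown leave open whether a longer chain such as hexyl would take the number lower still or whether the fall ends with the butyl and tert-butyl groups. They also leave open how a ring such as cyclohexyl, or a group carrying an amine or a carboxylic acid, would read at this same place on the ring.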